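The source may report more compounds than this note shows. Statements on the series, on what has been measured and on what is new or still open speak of the compounds shown alone.

The series shares one core, carrying at a single aromatic carbon a group that is varied from compound to compound. Compound 1 `COc1cccc(Oc2ccc3c(NCCCNCc4cccc(OC)c4O)ccnc3c2)c1` gives 9.28 in a physicochemical assay for acid dissociation. Compound 2 `COc1cccc(CNCCCNc2ccnc3cc(-c4cccc5ccccc45)ccc23)c1O` gives 9.47 in this assay, and compound 3 `COc1cccc(CNCCCNc2ccnc3cc(-c4ccc(C(C)(C)C)cc4)ccc23)c1O` gives 9.47 in this assay. The steps at that carbon were a number 0.19 log units higher from compound 1 to compound 2 (within the scatter), a number 0.19 log units higher from compound 1 to compound 3 (within the scatter) and no change at the digits printed from compound 2 to compound 3 (within the scatter), so compound 3 stands level with compound 2 at the digits shown and these two sit together at the top of the three numbers, with compound 1 the furthest from compound 3 by a gap that is still within the scatter.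

Compound 4 `COc1cccc(CNCCCNc2ccnc3cc(CCc4ccccc4)ccc23)c1O` differs from compound 3 at the same aromatic carbon: phenethyl in place of 4-(tert-butyl)phenyl on an aromatic carbon. All three measured steps concern changes at this very carbon, and every one of them stayed within the scatter. Compound 4 is therefore expected to give a number close to that of compound 3, with a step of a number 0.02 log units lower from compound 3 to compound 4 (within the scatter), no change beyond the scatter. The estimate for compound 4 in this assay is 9.45, ranging from 9.15 to 9.75.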

Compound 4, acid dissociation constant: 9.47
Estimate against measurement, compound 4: 0.02 log units below, within the range that was stated.
By their numbers in this assay, from the lowest: compounds 1, 2, 3 and 4 (each within the scatter of the next).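

Phenethyl holds its ring away from the core through a chain, unlike the directly attached rings of compound 2 and compound 3, and in this assay this link gives no change at the digits printed from compound 3 to compound 4 (within the scatter) and no change at the digits printed from compound 2 to compound 4 (within the scatter) as well. Measured against the oxygen-linked 3-methoxyphenoxy group, the same change gives a number 0.19 log units higher from compound 1 to compound 4 (within the scatter) in this assay and so stays within the scatter too. At this aromatic carbon, then, replacing a directly attached ring or an oxygen-linked ring with phenethyl produces no step beyond the scatter, even though the group entering has fewer heavy atoms than 4-(tert-butyl)phenyl.

Nothing available explains why these numbers stay so close. As far as these compounds go, all four groups are carbon-rich and contain an aromatic ring, so whether an amine, a carboxylic acid or a longer chain at this carbon would shift the number remains open.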